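Amidine series: removing the fluoro from compound 2

A few compounds are considered here, and "the series" means these few. Any claim that something is new, unique, unknown or untested is made for them only; others in the source may bear on it.

Of the compounds shown here, two have numbers so far, compound 1 `COc1ccc(-c2ccc(-c3ccc(C(=N)N)cc3)s2)cc1` and compound 2 `N=C(N)c1ccc(-c2ccc(-c3ccc(Cl)cc3)s2)cc1F`, which differ from each other in more than one place. In a functional assay on PC-3 cells (Homo sapiens) for inhibition, read by sulforhodamine B assay, with a stated time of 48 h (on this read-out lower numbers stand for stronger inhibition of growth and higher numbers for weaker inhibition of growth), compound 1 gives 773 nM. In this assay compound 2 gives 394 nM, the lowest of the two numbers; its gap to compound 1 lies within the scatter, so the two numbers give no order between them.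

Compound 3 `N=C(N)c1ccc(-c2ccc(-c3ccc(Cl)cc3)s2)cc1` is not yet measured. It differs from compound 2 by hydrogen in place of fluoro on an aromatic carbon. Going by the values given here, no step between measured compounds covers this change, so the numbers at hand cannot size it. A single change of this kind is expected to move the number little, if at all, beyond the scatter, with the more likely direction toward a somewhat higher number; from compound 2 to compound 3 the expected step is a 1.4-fold higher number from compound 2 to compound 3 (0.14 log units; within the scatter). Compound 3 is therefore estimated to give 550 nM, with a range from 220 nM to 1400 nM.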

Compound 3, concentration for 50% growth inhibition: 164 nM
Estimate against measurement, compound 3: 3.4-fold (0.53 log units) above; measured number below the stated range.
By their numbers in this assay, from the lowest: compound 3; then compounds 2 and 1 (each within the scatter of the next).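

In this assay the fluoro on the aromatic carbon, ortho to a group of 3 heavy atoms and meta to a large group, now has a measured step: hydrogen in its place gives a 2.4-fold lower number from compound 2 to compound 3 (0.38 log units; beyond the scatter), so within this pair the compound without fluoro is the stronger growth inhibitor. Going by these compounds alone, the new compound also provides the first single-place comparison for the substituent at the far end of the shared core, where chloro in place of methoxy gives a 4.7-fold lower number from compound 1 to compound 3 (0.67 log units; beyond the scatter), and with both steps beyond the scatter, compound 3 is the most potent of the three compounds. Nothing at hand accounts for either step.

On these data alone, each step rests on one pair, so it remains open whether the fluoro step would keep its direction with methoxy rather than chloro on the far aromatic ring, or whether the chloro step would hold with the fluoro present. Also open, as far as these compounds go, is how a methyl, a hydroxyl or an amine would compare with hydrogen and fluoro on the same aromatic carbon, and how a nitrile or a trifluoromethyl would compare with chloro.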